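The compounds below may be only part of what the source reports. "The series", "measured", "known", "first", "only" and "open" are said of these compounds alone.

Measured so far:
Compound 1 `COc1ccc(-c2ccnc(Nc3ccc([N+](=O)[O-])cc3)n2)cc1`: 2730 nM
Compound 2 `O=[N+]([O-])c1ccc(Nc2nccc(-c3ccc(Cl)c(Cl)c3)n2)cc1`: 720 nM

In a functional assay on A549 cells (Homo sapiens) for antiproliferative activity, read by MTT assay (on this read-out higher numbers stand for weaker inhibition and lower numbers for stronger inhibition), compound 2 has the lower of the two numbers, at 720 nM. Compound 3 `O=[N+]([O-])c1ccc(Nc2nccc(-c3ccc(Cl)cc3Cl)n2)cc1` has the same atoms as compound 2, joined differently: 2,4-dichlorophenyl in place of 3,4-dichlorophenyl on an aromatic carbon. In words, 2,4-dichlorophenyl sits in place of 3,4-dichlorophenyl on an aromatic carbon.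

Among the compounds with values here, only one measured step bears on this change: a 3.8-fold lower number from compound 1 to compound 2 (0.58 log units; beyond the scatter). It was a modest step, made at the same aromatic carbon, but it swapped one group for a quite different one. Here the two chlorine atoms stay and only one changes position. Within the data shown here, no measured compound carries the 2,4-dichlorophenyl group, so the direction is uncertain. A step smaller than the measured one is expected, leaning slightly towards a higher number. The expected step is a 1.5-fold higher number from compound 2 to compound 3 (0.18 log units; within the scatter). For compound 3 the estimate is 1100 nM, with an expected range from 350 nM to 3000 nM.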

Compound 3, half-maximal inhibitory concentration: 119000 nM
For compound 3 the middle estimate is 110-fold (2.03 log units) below the measured one, and the stated range ends below it.
By their numbers in this assay, from the lowest: compound 2; then compound 1; then compound 3.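

In this assay, within the data shown here, moving a single chlorine while keeping the same atoms gives a 170-fold higher number from compound 2 to compound 3 (2.22 log units; beyond the scatter) and is a large step, so the arrangement of the chlorines on this ring matters far more than the earlier compounds could show. Having two chlorines is not enough in itself: the 2,4-dichlorophenyl group also compares poorly with the 4-methoxyphenyl group, with a 44-fold higher number from compound 1 to compound 3 (1.64 log units; beyond the scatter) as the step between them, even though 3,4-dichlorophenyl gave the lowest number of the three. Nothing available here explains why this shift of one chlorine has such a large effect.

The compounds shown leave open whether a phenyl ring carrying only one chlorine would keep the low number of compound 2 or lose it. They also leave open how a fluorine, a methyl or an amine would behave in these ring positions.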